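The source may report more compounds than this note shows. Statements on the series, on what has been measured and on what is new or still open speak of the compounds shown alone.

Measured compounds:
- compound 1 `Cn1c(=O)c(S(=O)(=O)c2ccc(F)cc2F)cc2cnc(Nc3cccc4[nH]ccc34)nc21`: 750 nM
- compound 2 `Cn1c(=O)c(S(=O)(=O)c2ccc(F)cc2F)cc2cnc(Nc3ccc4occc4c3)nc21`: 15000 nM
- compound 3 `Cn1c(=O)c(S(=O)(=O)c2ccc(F)cc2F)cc2cnc(Nc3ccc4cccc(O)c4n3)nc21`: 5000 nM

In a functional assay on DU-145 cells (Homo sapiens) for inhibition, read by trypan blue exclusion, with a stated time of 72 h (a higher number here means a weaker inhibitor, a lower number a stronger inhibitor), compound 3 holds the second highest of the three numbers. Its steps are a 6.7-fold higher number from compound 1 to compound 3 (0.82 log units; beyond the scatter) and a 3.0-fold lower number from compound 2 to compound 3 (0.48 log units; beyond the scatter), so compound 3 sits between the other two, nearer to compound 2.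

Compound 4 `Cn1c(=O)c(S(=O)(=O)c2ccc(F)cc2F)cc2cnc(Nc3ccc4c(c3)C(=O)C(=O)N4)nc21` is the next member. The change from compound 3 is a group of 11 heavy atoms (8 carbon, 1 nitrogen, 2 oxygen; one five-membered non-aromatic ring with 1 hetero atom, one six-membered aromatic ring of carbon only) in place of a group of 11 heavy atoms (9 carbon, 1 nitrogen, 1 oxygen; one six-membered aromatic ring of carbon only, one six-membered aromatic ring with 1 hetero atom), on a nitrogen on an aromatic ring.

Within the data shown here, no measured step carries this exact exchange. The steps that do vary the group on the nitrogen are a 20-fold higher number from compound 1 to compound 2 (1.30 log units; beyond the scatter), a 6.7-fold higher number from compound 1 to compound 3 (0.82 log units; beyond the scatter) and a 3.0-fold lower number from compound 2 to compound 3 (0.48 log units; beyond the scatter), all beyond the scatter and ranging from modest to large. They show that this position is sensitive but give no direction for the entering group. The step from compound 3 to compound 4 in this assay is therefore expected to be small or none beyond the scatter, no change at the digits printed from compound 3 to compound 4 (within the scatter), with wide uncertainty. Compound 4 is estimated at 5000 nM, within 1500 nM to 15000 nM.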

Compound 4, half-maximal inhibitory concentration: 75000 nM
The estimate for compound 4 lay 15-fold (1.18 log units) below the measured number, outside the stated range (above it).
By their numbers in this assay, from the lowest: compound 1; then compound 3; then compound 2; then compound 4.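

In this assay the entering group gives a 15-fold higher number from compound 3 to compound 4 (1.18 log units; beyond the scatter) and a 5.0-fold higher number from compound 2 to compound 4 (0.70 log units; beyond the scatter) and a 100-fold higher number from compound 1 to compound 4 (2.00 log units; beyond the scatter), which leaves compound 4 as the weakest of the four, with each of its steps beyond the scatter. The groups exchanged between compound 3 and compound 4 have the same heavy-atom, hydrogen-bond donor and hydrogen-bond acceptor counts, so these counts alone do not set the number at this position. No measurement at hand accounts for the step.

The compounds shown leave open whether the higher number goes with the two carbonyl groups or with the five-membered non-aromatic ring of the entering group. They also leave open how a phenyl group carrying an amine or a carboxylic acid on this nitrogen would compare with compound 1 .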